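The compounds below may be only part of what the source reports. "The series", "measured", "known", "first", "only" and "open" are said of these compounds alone.

Measured so far in an in vivo ADME assay on the whole organism for metabolic stability, with Canis familiaris (Canis lupus familiaris) as the target, at a dose of 1 mg/kg by the intravenous route; a lower number here means that the compound disappears faster, a higher number that the compound lasts longer:
compound 1 `Cc1nc(-c2c(F)cccc2-c2ccc([C@@H](C)Nc3nccc(Cl)c3NC(=O)CC#N)cc2)no1`: 2 h
compound 2 `COC(=O)c1ccc(Cl)cc1-c1ccc([C@@H](C)Nc2nccc(Cl)c2NC(=O)CC#N)cc1`: 0.9 h

Compound 2 stands lowest of the two numbers; compound 1 is its nearest neighbour and sits higher by a margin beyond the scatter. Compound 3 `COC(=O)c1c(Cl)cccc1-c1ccc([C@@H](C)Nc2nccc(Cl)c2NC(=O)CC#N)cc1` differs from compound 2 in one place: 3-chloro-2-(methoxycarbonyl)phenyl in place of 5-chloro-2-(methoxycarbonyl)phenyl on an aromatic carbon. Among the measured compounds shown here, no step between two measured compounds covers this change, so its size is open. The change is expected to move this assay little, with a step from compound 2 to compound 3 of about a 1.1-fold higher number from compound 2 to compound 3 (0.05 log units; within the scatter) expected, not beyond the scatter in either direction. Compound 3 is therefore estimated at 1 h, with a range from 0.5 h to 2 h.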

Compound 3, half-life: 6.3 h
The estimate for compound 3 lay 6.3-fold (0.80 log units) below the measured number; the measured number lies above the stated range.
By their numbers in this assay, from the lowest: compound 2; then compound 1; then compound 3.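

In this assay, 3-chloro-2-(methoxycarbonyl)phenyl in place of 5-chloro-2-(methoxycarbonyl)phenyl gives a 7.0-fold higher number from compound 2 to compound 3 (0.85 log units; beyond the scatter). With the same atoms on both sides, the placement of the chlorine on this ring alone separates the two compounds by a margin beyond the scatter. No measurement shown here bears on the reason for this step.

From the compounds shown here alone, it remains open whether the step persists with a carboxylic acid or a primary amide in place of the methoxycarbonyl group. A chlorine at the remaining ring positions, or a methyl group in its place, is also untested in the compounds shown.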